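The source may report more compounds than this note shows. Statements on the series, on what has been measured and on what is new or still open speak of the compounds shown alone.

Compound 1, `NC(=O)Cc1cc(=O)oc2cc(OCc3ccccc3)ccc12`, is the reference point of this small set. In an assay (strain Wistar) for inhibition of Amine oxidase [flavin-containing] A (Rattus norvegicus) (a higher number here means a weaker inhibitor, a lower number a stronger inhibitor), compound 1 gives 8000 nM. Compound 2, `NC(=O)Cc1cc(=O)oc2cc(OCc3cccc(Cl)c3)ccc12`, differs from it by chloro in place of hydrogen on an aromatic carbon, and in this assay compound 2 gives 26000 nM; that change made a 3.3-fold higher number from compound 1 to compound 2 (0.51 log units; beyond the scatter). Compound 3, `NCc1cc(=O)oc2cc(OCc3ccccc3)ccc12`, carries a different chain on the shared core: the difference between the core of compound 1 and the core of compound 3 is amino in place of carbamoyl on a saturated chain carbon bound to an aromatic carbon. In this assay compound 3 gives 4400 nM, and the step is a 1.8-fold lower number from compound 1 to compound 3 (0.26 log units; within the scatter), so the two values cannot be told apart.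

Compound 4, `NCc1cc(=O)oc2cc(OCc3cccc(Cl)c3)ccc12`, has not yet been measured. It is related to compound 3 by chloro in place of hydrogen on an aromatic carbon. Among the measured compounds shown here, this is the same change as the one from compound 1 to compound 2, with the place described in the same words in both cases: on an aromatic carbon of a six-membered aromatic ring of carbon only, meta to a large group. The change occurs twice among these compounds, and only one of those occurrences is measured. Because a 3.3-fold higher number from compound 1 to compound 2 (0.51 log units; beyond the scatter) was a modest step, a step of similar size is expected here, namely a 3.0-fold higher number from compound 3 to compound 4 (0.47 log units; beyond the scatter). This rests on a single measured pair, so the range is kept wide. Compound 4 is therefore estimated at 13000 nM in this assay. The lower end of the estimate for compound 4 is 5000 nM. The upper end of the estimate for compound 4 is expected to be 35000 nM.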

Compound 4, half-maximal inhibitory concentration: 2000 nM
For compound 4 the middle estimate is 6.5-fold (0.81 log units) above the measured one; measured number below the stated range.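

In this assay, chloro in place of hydrogen on an aromatic carbon, the change from phenyl to 3-chlorophenyl, gave a 2.2-fold lower number from compound 3 to compound 4 (0.34 log units; beyond the scatter) and so ran opposite to the step seen on the core of compound 1: the same change on two cores in this assay, a 3.3-fold higher number (0.51 log units; beyond the scatter) from compound 1 to compound 2 and a 2.2-fold lower number (0.34 log units; beyond the scatter) from compound 3 to compound 4, 7.2-fold (0.85 log units) apart, beyond the scatter of two such steps. Read along the other edge of the same four compounds, amino in place of carbamoyl gave a 13-fold lower number from compound 2 to compound 4 (1.11 log units; beyond the scatter) with chloro present, a much larger step than the one seen without it: the same change on two cores in this assay, a 1.8-fold lower number (0.26 log units; within the scatter) from compound 1 to compound 3 and a 13-fold lower number (1.11 log units; beyond the scatter) from compound 2 to compound 4, 7.2-fold (0.85 log units) apart, beyond the scatter of two such steps. These results show that, among these four compounds, neither change can be carried from one core to another as a fixed step, but they do not show how the two changes interact, and the two comparisons are one closed set of four values rather than independent findings, so a single pair of cores cannot establish a rule for the series.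

The compounds shown leave open whether the reversal is specific to chloro or would also appear with fluoro, bromo or methyl in its place. They also leave open whether it would persist with a longer chain carrying the amine, or with a carboxylic acid in place of the amino group.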